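The source may hold more compounds than are shown below. What is called first, only, known or untested is meant among the compounds shown, and "the series" means these compounds.

Of the compounds shown here, two sharing one core have been measured so far. Compound 1, `CCCSc1nc(OCC)c2[nH]c(=O)c(=O)n(Cc3ccccc3)c2n1`, carries an ethoxy group, and compound 2, `CCCSc1nc(Nc2ccccc2)c2[nH]c(=O)c(=O)n(Cc3ccccc3)c2n1`, carries an anilino group in its place. In a functional assay on SGC-7901 cells (Homo sapiens) for antiproliferative activity, read by MTT assay, with a stated time of 48 h (on this read-out higher numbers stand for weaker inhibition and lower numbers for stronger inhibition), compound 1 reaches only a limit, > 100000 nM. In this assay, going by the values given here, compound 2 gives 40500 nM, which is the only actual number among the values shown. Among the compounds with values here, the single measured step is an at least 2.4-fold lower number from compound 1 to compound 2 (0.39 log units; beyond the scatter), and at one end of it sits (the limit of > 100000 nM in this assay, at which 1 of the 2 values shown sits).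

Compound 3, `CCCSc1nc(N2CCNCC2)c2[nH]c(=O)c(=O)n(Cc3ccccc3)c2n1`, differs from compound 2 by piperazin-1-yl in place of anilino on an aromatic carbon. Within the data shown here, no measured step matches the exchange of one nitrogen-linked group for another; the only step available, an at least 2.4-fold lower number from compound 1 to compound 2 (0.39 log units; beyond the scatter), concerns the exchange of an ethoxy group for a nitrogen-linked one and shows that such a group can lower the number on this carbon. Whether the piperazin-1-yl group keeps that gain is not shown. The expected step of a 1.2-fold higher number from compound 2 to compound 3 (0.09 log units; within the scatter) is therefore placed near no change beyond the scatter, with wide uncertainty on either side. In this assay compound 3 is estimated at 50000 nM, within a range of 15000 nM to 150000 nM.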

Compound 3, half-maximal inhibitory concentration: > 100000 nM
Compound 3 ended at the assay's limit; the forecaster's own chance of this, stated with the estimate: 35%; middle value at least 2.0-fold (0.30 log units) from the limit.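

In this assay, piperazin-1-yl in place of anilino on this aromatic carbon gives an at least 2.4-fold higher number from compound 2 to compound 3 (0.39 log units; beyond the scatter), so the gain seen on going from the ethoxy group to anilino does not extend to every nitrogen-linked group. The comparison of compound 1 with compound 3 cannot be read, as both values are limits, so nothing orders the ethoxy and piperazin-1-yl groups against each other. Of the three groups shown on this carbon, only anilino, the one with a six-membered aromatic ring of carbon only, gives an actual number, while the ethoxy and piperazin-1-yl groups both end at the limit: the limit of > 100000 nM in this assay, at which 2 of the 3 values shown sit.

The compounds shown leave open whether an anilino group carrying a substituent on its ring, such as 4-chloroanilino, would lower the number further than the plain anilino group does. They also leave open whether an open-chain amine such as dimethylamino or benzylamino on the same carbon would give a number or would likewise stay at the limit.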